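The source may report more compounds than this note shows. Statements on the series, on what has been measured and on what is new or still open speak of the compounds shown alone.

Measured so far:
- compound 1 `COc1cc2c(cc1OC)C(=O)C(C(=O)Nc1ccc(F)cc1)C2`: 55 ug/mL
- compound 2 `COc1cc2c(cc1OC)C(=O)C(C(=O)Nc1cccc(Cl)c1)C2`: 76.3 ug/mL

In a physicochemical assay, with a stated time of 30 min (a higher number here means a weaker inhibitor, a lower number a stronger inhibitor), compound 2 at 76.3 ug/mL stands within the scatter of compound 1. Compound 3 `COc1cc2c(cc1OC)C(=O)C(C(=O)Nc1cccc(Br)c1)C2` has bromo in place of chloro on an aromatic carbon, meta to a large group (bromo in place of chloro on an aromatic carbon). Within the data shown here, the only measured step bearing on this change is a 1.4-fold higher number from compound 1 to compound 2 (0.14 log units; within the scatter), which exchanged 4-fluorophenyl for 3-chlorophenyl. Among the measured compounds shown here, with only that step to go on, no change beyond the scatter is expected in this assay. The expected step is a 1.0-fold lower number from compound 2 to compound 3 (0.01 log units; within the scatter). For compound 3 the estimate is 75 ug/mL, with an expected range of 45 ug/mL to 125 ug/mL.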

Compound 3, half-maximal inhibitory concentration: 58.9 ug/mL
Compound 3: middle estimate off by 1.3-fold (0.10 log units), on the high side, within the range that was stated.
By their numbers in this assay, from the lowest: compounds 1, 3 and 2 (each within the scatter of the next).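

In this assay, among these compounds, the first exchange of one halogen for another at the same ring position, bromo in place of chloro, gives a 1.3-fold lower number from compound 2 to compound 3 (0.11 log units; within the scatter). Replacing 4-fluorophenyl with 3-bromophenyl gives a 1.1-fold higher number from compound 1 to compound 3 (0.03 log units; within the scatter), so all three halogenated phenyl amides so far remain indistinguishable in this assay. No measured evidence bears on this result.

As far as these compounds go, whether a non-halogen group at this ring position, such as an amine or a carboxylic acid, would produce a step beyond the scatter remains open. From the compounds shown here alone, the contribution of the amide hydrogen and of the shared core is also open.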